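The compounds below may be only part of what the source reports. "The series", "measured", "known", "first", "only" and "open" are said of these compounds alone.

Among the measured compounds shown here, in a functional assay on A549 cells (Homo sapiens) for inhibition (a higher number here means a weaker inhibitor, a lower number a stronger inhibitor), the two compounds tested so far give no number. Compound 1, `CCN(CC)c1cc(/C=C/c2ccc3ccccc3c2)ccc1OC`, reads > 5000 nM, which is a limit of the assay. Compound 2, `COc1cc(/C=C\c2ccc3c(ccn3S(=O)(=O)c3ccccc3)c2)cc(OC)c1OC`, reads > 5000 nM, again a limit and not a number. Both therefore stand at the same mark, (the limit of > 5000 nM in this assay, at which 2 of the 2 values shown sit).

Compound 3, `COc1cc(/C=C\c2ccc3[nH]ccc3c2)cc(OC)c1OC`, has not yet been measured. It differs from compound 2 by one change: hydrogen in place of phenylsulfonyl on an aromatic nitrogen. In words, it has hydrogen in place of phenylsulfonyl on an aromatic nitrogen. For the measured compounds named here, no measured pair shows this change, so the size of the step remains a judgement. With compound 2 at its limit of > 5000 nM, only a move towards stronger inhibition could be read as a clear change. A large move in that direction is expected, and the estimated step is an at least 33-fold lower number from compound 2 to compound 3 (1.52 log units; beyond the scatter). For compound 3 the estimated value is 150 nM, with an expected range of 15 nM to 3000 nM.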

Compound 3, half-maximal inhibitory concentration: 390 nM
For compound 3 the middle estimate is 2.6-fold (0.41 log units) below the measured one; the measured number falls inside the stated range.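

In this assay compound 3 is the first of the compounds shown to give a number rather than a limit, so the aromatic nitrogen of the five-membered ring is a place where a change can be read. Hydrogen in place of phenylsulfonyl there gives an at least 12-fold lower number from compound 2 to compound 3 (1.10 log units; beyond the scatter) and this large step is the only one available so far. Compound 2 reads > 5000 nM which is a limit and not a number, so the step is only a minimum, and that mark is a common one here: the limit of > 5000 nM in this assay, at which 2 of the 3 values shown sit.

On these data alone, it remains open whether the gain depends on the hydrogen on that nitrogen or only on the loss of phenylsulfonyl. A methyl or acetyl group at the same place, or a methanesulfonyl group, would separate these two readings.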